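The compounds below may be only part of what the source reports. "The series", "measured", "known", "first", "only" and "open" are said of these compounds alone.

Measured compounds:
compound 1 `O=C(O)CC/C=C\CO[C@H]1C(OCc2ccc(-c3ccc(CO)cc3)cc2)CC[C@@H]1N1CCCCCC1`: 3.16 nM
compound 2 `CC(=O)NCc1ccccc1-c1ccc(COC2CC[C@H](N3CCCCCC3)[C@H]2OC/C=C\CCC(=O)O)cc1`: 25.1 nM
compound 3 `CS(=O)(=O)Nc1cccc(-c2ccc(COC3CC[C@H](N4CCCCCC4)[C@H]3OC/C=C\CCC(=O)O)cc2)c1`: 12.6 nM

In a functional assay on blood for antagonist activity at thromboxane A2 receptor (Homo sapiens) (on this read-out lower numbers stand for tighter binding and higher numbers for weaker binding), compound 1 gives 3.16 nM, the lowest of the three numbers. Compound 3 stands nearest to it (a 4.0-fold higher number from compound 1 to compound 3 (0.60 log units; beyond the scatter)) and compound 2 furthest (a 7.9-fold higher number from compound 1 to compound 2 (0.90 log units; beyond the scatter)). Compound 4 `O=C(O)CC/C=C\CO[C@H]1[C@@H](OCc2ccc(-c3ccc(CO)cc3)cc2)CC[C@@H]1N1CCCCCC1` differs from compound 1 in this way: the two compounds have the same atoms and bonds; at least one stereo element is drawn with a configuration in one of them and without one in the other: 1 of 4 stereo elements differ; a stereocentre at a saturated ring carbon is drawn without a configuration in compound 1 and S in compound 4. Among the compounds with values here, none of the measured steps touches a stereo element; each of them exchanges a group on an aromatic carbon, so none of them bears directly on the step to compound 4. The two compounds share all their atoms and bonds. No step beyond the scatter in this assay is expected for compound 4. Compound 4 is therefore estimated at 2.5 nM, with a range from 1 nM to 8 nM. The expected step is a 1.3-fold lower number from compound 1 to compound 4 (0.10 log units; within the scatter).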

Compound 4, dissociation constant: 3.98 nM
Compound 4: middle estimate off by 1.6-fold (0.20 log units), on the low side; low and high end bracket the measured number.
By their numbers in this assay, from the lowest: compounds 1 and 4 (each within the scatter of the next); then compounds 3 and 2 (each within the scatter of the next).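

In this assay, the S configuration drawn at the saturated ring carbon of compound 4 gives no separation from compound 1, with a 1.3-fold higher number from compound 1 to compound 4 (0.10 log units; within the scatter). Within the data shown here, the earlier steps each exchanged a group on an aromatic carbon, so this is the first reading at a stereo element, and it shows no step beyond the scatter there. The reading is limited to this comparison: the fact that one of compounds 1 and 4 is drawn with a defined configuration and the other without, at the place where they differ.

The compounds shown leave open how the R configuration at this carbon would read. They also leave open how a 4-carboxyphenyl or 4-(aminomethyl)phenyl group would compare with 4-(hydroxymethyl)phenyl.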